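Weak antiproliferative quinone series: the step to compound 4

A few compounds are considered here, and "the series" means these few. Any claim that something is new, unique, unknown or untested is made for them only; others in the source may bear on it.

Compound 1 `CCC1=C(O)c2c(oc(-c3cccc(OC(F)(F)F)c3)cc2=O)C(CC)(CC)C1=O`: in a functional assay on KB cells (Homo sapiens) for antiproliferative activity, read by sulforhodamine B assay, with a stated time of 3 days (on this read-out lower numbers stand for an effect already at smaller amounts and higher numbers for an effect only at larger amounts of compound), compound 1 gives > 47.4 uM, a limit of the assay rather than a number.
Compound 2 `CCC1=C(O)c2c(oc(-c3ccccc3C(F)(F)F)cc2=O)C(CC)(CC)C1=O`: in this assay compound 2 gives 45.6 uM.
Compound 3 `CCC1=C(O)c2c(oc(-c3ccccc3F)cc2=O)C(CC)(CC)C1=O`: in this assay compound 3 gives > 56.2 uM, again a limit of the assay rather than a number.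

Compound 3 therefore stands only at a limit in this assay, and one further value among the three shown is a limit as well. Within the data shown here, the single measured step that reaches compound 3 is an at least 1.2-fold higher number from compound 2 to compound 3 (0.09 log units; that floor lies within the scatter), a step whose floor does not leave the scatter. Two of the three values sit at the edge of what the assay reports: the limit of > 47.4 uM in this assay, at which 1 of the 3 values shown sits, describes one such case, and the limit of > 56.2 uM in this assay, at which 1 of the 3 values shown sits, the other. Within this set nothing separates the three compounds beyond the scatter.

Compound 4 `CCC1=C(O)c2c(oc(-c3ccc(F)c(C)c3)cc2=O)C(CC)(CC)C1=O` is to be measured next. It differs from compound 3 by 4-fluoro-3-methylphenyl in place of 2-fluorophenyl on an aromatic carbon. Among the measured compounds shown here, no measured step covers this exchange, and the only step touching compound 3 is small; the expectation is therefore no movement beyond the scatter, a step of an at least 1.1-fold lower number from compound 3 to compound 4 (0.05 log units; that floor lies within the scatter). Compound 4 is expected to give about 50 uM in this assay, estimated between 20 uM and 110 uM.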

Compound 4, concentration for half-maximal effect: 40.5 uM
For compound 4 the middle estimate is 1.2-fold (0.09 log units) above the measured one, within the range that was stated.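

In this assay, 4-fluoro-3-methylphenyl in place of 2-fluorophenyl, on the aromatic carbon next to the ring oxygen, gives an at least 1.3-fold lower number from compound 3 to compound 4 (0.14 log units; that floor lies within the scatter). What this adds is that the position accepts a phenyl group carrying two substituents, and compound 4 returns a measured number where compound 3 reached only a limit of the assay, yet nothing in the step leaves the scatter, so the series remains weak in this read-out. The full size of the step cannot be read, because the starting point of the comparison, compound 3, is a limit and not a number: the limit of > 56.2 uM in this assay, at which 1 of the 4 values shown sits.

The exchange alters two things at once, adding a methyl group and changing where the fluorine stands on the phenyl ring, and the compounds shown do not separate these two changes. Going by these compounds, it also stays open whether an amine or a carboxylic acid on that phenyl ring, or a phenyl group replaced by a longer chain at the same carbon, would move the number in this read-out beyond the scatter.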